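Replacing Isopropyl with Methyl on a Nitrogen

This account rests on a few compounds, and the source may have more. Where it says the series, first, only, none or still open, it means among the compounds named here.

Three compounds sharing one core have so far been examined in a functional assay on MDA-MB-435 cells (Homo sapiens) for inhibition, read by sulforhodamine B assay, with a stated time of 48 h (a lower number here means that less compound is needed, a higher number that more compound is needed for the effect), with mixed results. Compound 1 `COc1ccc(Nc2ncnc3occ(C)c23)cc1` has the entry "not determined" (no result reported) and offers no number. Compound 2 `CSc1ccc(N(C)c2ncnc3occ(C)c23)cc1` gives 12.3 nM in this assay as its result. Compound 3 `COc1ccc(N(c2ncnc3occ(C)c23)C(C)C)cc1` gives 504 nM in this assay and so holds the higher of the two numbers, beyond the scatter from compound 2. Compound 4 `COc1ccc(N(C)c2ncnc3occ(C)c23)cc1` awaits measurement and differs from compound 3 as follows: methyl in place of isopropyl on a nitrogen on an aromatic ring. Compound 2 also carries methyl on that nitrogen and stands at 12.3 nM so a fall beyond the scatter is expected. The expected step is a 42-fold lower number from compound 3 to compound 4 (1.62 log units; beyond the scatter) in the direction of a lower number. For compound 4 the estimated value is 12 nM with an expected range from 4 nM to 40 nM in this measurement.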

Compound 4, half-maximal effective concentration: 4.3 nM
Beside the measured number, compound 4's estimate is 2.8-fold (0.45 log units) above it; measured number inside the range.
By their numbers in this assay, from the lowest: compound 4; then compound 2; then compound 3.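

In this assay, putting methyl in place of isopropyl on the nitrogen gives a 120-fold lower number from compound 3 to compound 4 (2.07 log units; beyond the scatter), the first step read at this position. Methoxy in place of methylsulfanyl on an aromatic carbon, with methyl kept on the nitrogen, gives only a 2.9-fold lower number from compound 2 to compound 4 (0.46 log units; beyond the scatter), so the change on the nitrogen is the much larger of the two. Nothing available explains either step. As far as these compounds go, what an ethyl group or a longer chain on that nitrogen would give stays open, as does an amine or a carboxylic acid in place of the methoxy.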